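Swapping 2-methoxyphenyl for 4-cyanophenyl on the amide-type nitrogen

The source may report more compounds than this note shows. Statements on the series, on what has been measured and on what is new or still open speak of the compounds shown alone.

Compound 1 `Cc1ccc(NC(=O)C2CCN(C/C=C/c3ccccc3)CC2)cc1`: 33900 nM
Compound 2 `CCCCCc1ccc(NC(=O)C2CCN(C/C=C/c3ccccc3)CC2)cc1`: 2890 nM
Compound 3 `COc1ccccc1NC(=O)C1CCN(C/C=C/c2ccccc2)CC1`: 91200 nM

In a functional assay on HepG2 cells (Homo sapiens) for inhibition, read by MTT assay, with a stated time of 72 h (a higher number here means a weaker inhibitor, a lower number a stronger inhibitor), compound 3 gives 91200 nM, the highest of the three numbers. Compound 4 `N#Cc1ccc(NC(=O)C2CCN(C/C=C/c3ccccc3)CC2)cc1` has 4-cyanophenyl in place of 2-methoxyphenyl on an amide-type nitrogen. The closest evidence is the modest 2.7-fold higher number from compound 1 to compound 3 (0.43 log units; beyond the scatter), which places 2-methoxyphenyl where 4-methylphenyl stood on that nitrogen. The large 12-fold lower number from compound 1 to compound 2 (1.07 log units; beyond the scatter) extends a chain that compound 4 lacks, so it bears little on this change. Within the data shown here, no measured compound carries a nitrile. A modest move to a lower number is therefore expected, an estimated 2.3-fold lower number from compound 3 to compound 4 (0.36 log units; beyond the scatter). For compound 4 the estimated value is 40000 nM, with an expected range of 14000 nM to 100000 nM.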

Compound 4, half-maximal inhibitory concentration: 38300 nM
Compound 4: the middle estimate sits 1.0-fold (0.02 log units) above what was measured; the range from low to high includes it.
By their numbers in this assay, from the lowest: compound 2; then compounds 1 and 4 (each within the scatter of the next); then compound 3.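

In this assay the change from 2-methoxyphenyl to 4-cyanophenyl on the amide-type nitrogen moves the number down (a 2.4-fold lower number from compound 3 to compound 4 (0.38 log units; beyond the scatter)). Cyano and methyl on the aromatic carbon give values within the scatter of each other (a 1.1-fold higher number from compound 1 to compound 4 (0.05 log units; within the scatter)), whereas pentyl stands clearly apart from cyano (a 13-fold higher number from compound 2 to compound 4 (1.12 log units; beyond the scatter)). Nothing available explains these differences. The compounds shown leave open whether an amine or a carboxylic acid on that aromatic carbon would match cyano and methyl or pentyl, and whether a chain longer than pentyl would lower the number further.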